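This account rests on a few compounds, and the source may have more. Where it says the series, first, only, none or still open, it means among the compounds named here.

Compound 3, `CN(C)CC[C@@H]1C[C@@H](c2ccc(Cl)c(Cl)c2)[C@H](NC(=O)c2cc(-c3c(Cl)cnn3C)c(Cl)o2)CN1`, gives 3.4 nM in an assay for inhibition of RAC-alpha serine/threonine-protein kinase (Homo sapiens), read by HTRF, with a stated time of 1 h; on this read-out higher numbers stand for weaker inhibition and lower numbers for stronger inhibition. That is the lowest of the three numbers measured, yet its steps to compound 1, `Cn1ncc(Cl)c1-c1cc(C(=O)N[C@@H]2CN[C@H](CCN3CCC(O)CC3)C[C@H]2c2ccc(Cl)c(Cl)c2)oc1Cl`, at 5.99 nM, and to compound 2, `Cn1ncc(Cl)c1-c1cc(C(=O)N[C@@H]2CN[C@H](CCN3CCCC3)C[C@H]2c2ccc(Cl)c(Cl)c2)oc1Cl`, at 6.41 nM, are both within the scatter, so the three stand together. Compound 4, `Cn1ncc(Cl)c1-c1cc(C(=O)N[C@@H]2CN[C@H](CC(=O)NCCO)C[C@H]2c2ccc(Cl)c(Cl)c2)oc1Cl`, differs from compound 3 as follows: (2-hydroxyethyl)carbamoyl in place of (dimethylamino)methyl on a saturated chain carbon bound to a saturated ring carbon.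

The measured steps all exchange one amine head group on the side chain for another: a 1.1-fold higher number from compound 1 to compound 2 (0.03 log units; within the scatter), a 1.8-fold lower number from compound 1 to compound 3 (0.25 log units; within the scatter), and a 1.9-fold lower number from compound 2 to compound 3 (0.28 log units; within the scatter). Each of them stays within the scatter, which shows that the identity of the amine at the chain end matters little here. Among the measured compounds shown here, the change to compound 4 is of another kind, since the (dimethylamino)methyl group leaves entirely and an amide carrying a hydroxyl enters, and no measured step covers such an exchange. The expectation is therefore uncertain: the number for compound 4 is expected to rise modestly, a 4.4-fold higher number from compound 3 to compound 4 (0.64 log units; beyond the scatter), with a wide band around it. Compound 4 is estimated at 15 nM, between 4 nM and 60 nM.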

Compound 4, half-maximal inhibitory concentration: 1.41 nM
Compound 4: middle estimate off by 11-fold (1.03 log units), on the high side; the whole stated range lies above it.
By their numbers in this assay, from the lowest: compound 4; then compounds 3, 1 and 2 (each within the scatter of the next).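

In this assay, compounds 1, 2 and 3 all end their side chain in an amine, and exchanging one amine for another stayed within the scatter. Compound 4 shows that this position also tolerates a group of another kind, since (2-hydroxyethyl)carbamoyl leaves no amine at the chain end and the number falls beyond the scatter, though modestly, with a 2.4-fold lower number from compound 3 to compound 4 (0.38 log units; beyond the scatter) and a 4.5-fold lower number from compound 2 to compound 4 (0.66 log units; beyond the scatter) and a 4.2-fold lower number from compound 1 to compound 4 (0.63 log units; beyond the scatter) as the three steps. Nothing available here accounts for this fall.

Going by these compounds, it stays open which part of the new group matters: a methylcarbamoyl group would test the amide without the hydroxyl, and a carboxylic acid would test the carbonyl without the amide hydrogen. On these data alone, a longer chain between the amide nitrogen and the hydroxyl is also open.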